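Hydroxyl moved on the benzylamine arm: toxicity outlook

A few compounds are considered here, and "the series" means these few. Any claim that something is new, unique, unknown or untested is made for them only; others in the source may bear on it.

Compound 1 `O=c1cc(CNCc2ccccc2O)oc2ccc(O)c(O)c12` — > 100000 nM, a limit
Compound 2 `O=c1cc(CNCc2cccc(F)c2)oc2ccc(O)c(O)c12` — > 100000 nM, a limit
Compound 3 `O=c1cc(CNCc2ccc(Br)cc2)oc2ccc(O)c(O)c12` — > 100000 nM, a limit

All three measured compounds share the core of compound 1 and differ only in the aryl group on a saturated chain carbon bound to an amine nitrogen. In an ADME assay on Huh-7 cells (Homo sapiens) for cytotoxicity (on this read-out lower numbers stand for higher toxicity in this test and higher numbers for lower toxicity in this test), compound 1 gives > 100000 nM, which is a limit of the assay and not a number. Compound 2 likewise returns only a limit, > 100000 nM. Compound 3 also stops at a limit, > 100000 nM. Because every value sits at the limit of > 100000 nM in this assay, at which 3 of the 3 values shown sit, the steps a step that the two limits leave unreadable from compound 1 to compound 2, a step that the two limits leave unreadable from compound 1 to compound 3 and a step that the two limits leave unreadable from compound 2 to compound 3 remain unreadable: none of the three aryl exchanges produced a measurable toxicity.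

Compound 4 `O=c1cc(CNCc2ccc(O)cc2)oc2ccc(O)c(O)c12` is the next candidate. It differs from compound 1 as follows: 4-hydroxyphenyl in place of 2-hydroxyphenyl on a saturated chain carbon bound to an amine nitrogen. All measured steps bear on it, since they are aryl exchanges at the same place, yet none gave a readable size. The expected step of a number no higher from compound 1 to compound 4 (the limit leaves the size open) is therefore none beyond the scatter, with compound 4 expected to stay at the limit as well. The estimate for compound 4 is 100000 nM, with a range from 50000 nM to 200000 nM.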

Compound 4, half-maximal cytotoxic concentration: 62700 nM
Beside the measured number, compound 4's estimate is 1.6-fold (0.20 log units) above it; the measured number falls inside the stated range.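

For the compounds shown here, compound 4 is the first compound here to return a number and not a limit in this assay, so this aryl position can yield a readable value, and 4-hydroxyphenyl in place of 2-hydroxyphenyl on a saturated chain carbon bound to an amine nitrogen comes out as an at least 1.5-fold lower number from compound 1 to compound 4 (0.20 log units; that floor lies within the scatter). The comparisons with the other two compounds read the same way, as an at least 1.5-fold lower number from compound 2 to compound 4 (0.20 log units; that floor lies within the scatter) and as an at least 1.5-fold lower number from compound 3 to compound 4 (0.20 log units; that floor lies within the scatter). These floors do not establish a real difference at this position, and the true sizes stay open because the other three compounds end at a limit: the limit of > 100000 nM in this assay, at which 3 of the 4 values shown sit.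

The compounds shown leave open whether 3-hydroxyphenyl at the same place would also give a number or would stop at a limit. They also leave open whether a carboxylic acid or a methoxy group on the aryl ring, or a longer chain between the aryl ring and the amine nitrogen, would move the read-out in this assay beyond the scatter.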